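A few compounds are considered here, and "the series" means these few. Any claim that something is new, unique, unknown or untested is made for them only; others in the source may bear on it.

Measured compounds:
Compound 1, `CCCCCCCCCCCCCCCCCC1OCC(COCCCCCC[N+](C)(C)C)O1`. In a functional assay on artery with platelet-activating factor receptor (Rattus norvegicus) as the target (a higher number here means that more compound is needed for the effect, a lower number that less compound is needed), compound 1 gives > 5 mg/kg, which is a limit of the assay and not a number.
Compound 2, `CCCCCCCCCCCCCCCCCC1OCC(COCCCCCC[n+]2ccccc2)O1`. In this assay compound 2 gives > 5 mg/kg, again a limit of the assay.
Compound 3, `CCCCCCCCCCCCCCCCCC1OCC(COC(=O)CCCCC[n+]2ccsc2)O1`. In this assay compound 3 gives 0.88 mg/kg.

Going by the values given here, compound 3 therefore holds the only number in the set; the other two values are limits, as noted in the limit of > 5 mg/kg in this assay, at which 2 of the 3 values shown sit. The step that the two limits leave unreadable from compound 1 to compound 2 sits between two limits and cannot be read. The steps of an at least 5.6-fold lower number from compound 1 to compound 3 (0.75 log units; beyond the scatter) and an at least 5.6-fold lower number from compound 2 to compound 3 (0.75 log units; beyond the scatter) both exchange the cationic head group on the ester oxygen and both run to a lower number.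

Compound 4, `CCCCCCCCCCCCCC1OCC(COC(=O)CCCCC[n+]2ccsc2)O1`, keeps the head group of compound 3 and differs only in the long chain: hydrogen in place of butyl on a saturated chain carbon, ten or more bonds along the chain from a saturated ring carbon. Among the compounds with values here, none of the measured steps touches this chain; all three vary the head group. No size or direction for the step to compound 4 can be read from the measured compounds, so the expectation rests on compound 3 alone. Compound 4 is expected to give about 1.2 mg/kg in this assay, within 0.4 mg/kg to 4 mg/kg. The expected step of a 1.4-fold higher number from compound 3 to compound 4 (0.13 log units; within the scatter) is set as none beyond the scatter, with a wide range that reflects the absence of any measured step on this chain.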

Compound 4, dose for 50% inhibition: > 5 mg/kg
Compound 4 was reported as a limit; the forecaster's own chance of this, stated with the estimate: 20%; middle value at least 4.1-fold (0.61 log units) away from the limit.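

Going by these compounds alone, the long chain, which none of the earlier steps touched, proves to matter in this assay: with hydrogen in place of butyl on this chain, the result is an at least 5.6-fold higher number from compound 3 to compound 4 (0.75 log units; beyond the scatter). Compound 4 gives > 5 mg/kg, which is a limit of the assay and not a number, so the true size of this step cannot be read. The head group of compound 3 is thus not enough on its own to keep a measurable number when the chain is cut back, and the only number in the series now depends on both the head group and the full chain, with the remaining compounds sitting at one ceiling: the limit of > 5 mg/kg in this assay, at which 3 of the 4 values shown sit.

From the compounds shown here alone, whether a chain longer than that of compound 3 would lower the number further, or a chain of intermediate length would hold it, stays open. Also open, going by these compounds, is what the ester carbonyl contributes separately from the ring on the cationic head, as the steps to compound 3 change both together, and whether a simple tertiary amine at the chain end could replace that head.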